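The source may report more compounds than this note shows. Statements on the series, on what has been measured and on what is new or still open speak of the compounds shown alone.

Compound 1 `CCOC(=O)c1c(-c2cc(F)cc(OC)c2)[nH]c2cc(OC)ccc2c1=O` carries a 3-fluoro-5-methoxyphenyl group on the shared core. In an ADME assay on HEK293 cells (Homo sapiens) for cytotoxicity, read by luminescence, with a stated time of 72 h (a higher number here means that more compound is needed for the effect, a lower number that less compound is needed), compound 1 gives > 22000 nM, which is a limit of the assay rather than a number. Compound 2 `CCOC(=O)c1c(-c2cccc(OC)c2)[nH]c2cc(OC)ccc2c1=O` differs from it by hydrogen in place of fluoro on an aromatic carbon. In this assay compound 2 gives > 22000 nM, again a limit. Compound 3 `CCOC(=O)c1c(-c2cccc(Oc3ccccc3)c2)[nH]c2cc(OC)ccc2c1=O` follows with phenyl in place of methyl on an oxygen on an aromatic ring. In this assay compound 3 gives > 22000 nM, also a limit. The step that the two limits leave unreadable from compound 1 to compound 2 and the step that the two limits leave unreadable from compound 2 to compound 3 therefore cannot be sized; what is known of them is summed up by the limit of > 22000 nM in this assay, at which 3 of the 3 values shown sit. Compound 4 `CCOC(=O)c1c(-c2cccc(Br)c2)[nH]c2cc(OC)ccc2c1=O` has not yet been measured. Its change from compound 1 is 3-bromophenyl in place of 3-fluoro-5-methoxyphenyl on an aromatic carbon. Among the compounds with values here, none of the measured steps covers this change, and none has a readable size, so the expected size of a step that the limit leaves unreadable from compound 1 to compound 4 rests only on every value so far sitting at the limit, with no direction that can be read. Compound 4 is therefore expected to give about 30000 nM in this assay, within a range from 12000 nM to 100000 nM, the most likely outcome being another limit rather than a number.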

Compound 4, half-maximal effective concentration: > 22000 nM
Compound 4: no number, only a limit; the forecaster's own chance of this, stated with the estimate: 80%; the middle value does not contradict the limit.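

In this assay compound 4 gives > 22000 nM, a limit of the assay and not a number. Within the data shown here, no step from compound 1, compound 2 or compound 3 to compound 4 can be read, and the picture stays as it was: the limit of > 22000 nM in this assay, at which 4 of the 4 values shown sit. The compounds shown leave open whether any of these changes on the shared core alters the half-maximal effective concentration at all.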